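Aryl replacements para on the anilide of the shared core

The source may report more compounds than this note shows. Statements on the series, on what has been measured and on what is new or still open speak of the compounds shown alone.

Measured compounds:
- compound 1, `CC(C)C[C@H](N)CN(C(=O)[C@@H]1C[C@H]1c1ccccc1)c1ccc(-c2ccccc2)cc1`: 880 nM
- compound 2, `CC(C)C[C@H](N)CN(C(=O)[C@@H]1C[C@H]1c1ccccc1)c1ccc(-c2cccnc2)cc1`: 10000 nM
- compound 3, `CC(C)C[C@H](N)CN(C(=O)[C@@H]1C[C@H]1c1ccccc1)c1ccc(C2=CCCCCC2)cc1`: 2100 nM

In a functional assay for agonist activity at G protein-coupled receptor 88 (Homo sapiens), read by HTRF and cAMP accumulation (a higher number here means that more compound is needed for the effect, a lower number that less compound is needed), compound 3 stands second highest of the three numbers; its nearest neighbour is compound 1, with a 2.4-fold higher number from compound 1 to compound 3 (0.38 log units; beyond the scatter) separating them, and its furthest is compound 2, with a 4.8-fold lower number from compound 2 to compound 3 (0.68 log units; beyond the scatter).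

Compound 4, `COc1cccc(-c2ccc(N(C[C@@H](N)CC(C)C)C(=O)[C@@H]3C[C@H]3c3ccccc3)cc2)c1`, is not yet measured. It differs from compound 3 in one place: 3-methoxyphenyl in place of cyclohept-1-en-1-yl on an aromatic carbon.

Within the data shown here, two measured steps bear on this change. The step of a 2.4-fold higher number from compound 1 to compound 3 (0.38 log units; beyond the scatter) shows that moving from phenyl to cyclohept-1-en-1-yl raised the number modestly, so a return to a six-membered aromatic ring of carbon only may recover part of that. Among the measured compounds shown here, the step of an 11-fold higher number from compound 1 to compound 2 (1.06 log units; beyond the scatter) shows that a pyridin-3-yl at the same place raised the number strongly, but compound 4 keeps a carbon-only aromatic ring with a single additional hydrogen-bond acceptor in the methoxy group, and no measured compound tests a substituent on that ring. The expected step is therefore a 2.1-fold lower number from compound 3 to compound 4 (0.32 log units; beyond the scatter), a modest lowering in this assay, near the edge of the scatter. Compound 4 is estimated at 1000 nM, within a range of 350 nM to 3500 nM.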

Compound 4, half-maximal effective concentration: 1100 nM
Estimate against measurement, compound 4: 1.1-fold (0.04 log units) below; measured number inside the range.
By their numbers in this assay, from the lowest: compounds 1, 4 and 3 (each within the scatter of the next, the first and the last beyond it); then compound 2.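

In this assay, among these compounds, methoxy in place of hydrogen gives a 1.3-fold higher number from compound 1 to compound 4 (0.10 log units; within the scatter) and is the first substituent tested on this aromatic ring, so the two compounds cannot be told apart. The swap of cyclohept-1-en-1-yl for 3-methoxyphenyl gives a 1.9-fold lower number from compound 3 to compound 4 (0.28 log units; within the scatter) and likewise does not separate that pair. The step to pyridin-3-yl remains the only large one here, with 3-methoxyphenyl in place of pyridin-3-yl giving a 9.1-fold lower number from compound 2 to compound 4 (0.96 log units; beyond the scatter), so the high number of compound 2 does not carry over to this oxygen-bearing aromatic ring.

Still open, going by these compounds, is whether an amine, a carboxylic acid or a longer chain such as butoxy in place of the methoxy would keep the number of compound 4. Nothing available explains any of these steps.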